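A Bromophenyl Variant Follows a Thiophene Compound

This account rests on a few compounds, and the source may have more. Where it says the series, first, only, none or still open, it means among the compounds named here.

Compound 3 `c1cn2cc(-c3ccsc3)nc(-c3ccc4ncn(C5CCCCC5)c4c3)c2n1` gives 0.39% in a functional assay on SNB-19 cells (Homo sapiens) for inhibition, read by sulforhodamine B assay, with a stated time of 48 h, tested at 10 uM (on this read-out higher numbers stand for more inhibition at the one concentration tested (going by the name of the read-out) and lower numbers for less inhibition), the smallest number of the three, though within the scatter of compound 2 `c1ccc2c(-c3cn4ccnc4c(-c4ccc5ncn(C6CCCCC6)c5c4)n3)cccc2c1`, which gives 9.08%; compound 1 `COc1ccc(-c2cn3ccnc3c(-c3ccc4ncn(C5CCCCC5)c4c3)n2)cc1` gives 68.4%. The steps down to compound 3 are a number 68 percentage points lower from compound 1 to compound 3 (beyond the scatter) and a number 8.7 percentage points lower from compound 2 to compound 3 (within the scatter). Compound 4 `Brc1ccc(-c2cn3ccnc3c(-c3ccc4ncn(C5CCCCC5)c4c3)n2)cc1` differs from compound 3 by 4-bromophenyl in place of thiophen-3-yl on an aromatic carbon. The step of a number 68 percentage points lower from compound 1 to compound 3 (beyond the scatter) bears most on this change. Compound 1 gives 68.4% with a six-membered aromatic ring of carbon only in the same place, while compound 2 shows that a carbon-only ring does not guarantee a higher number. A step of a number 39.6 percentage points higher from compound 3 to compound 4 (beyond the scatter) is therefore expected, upward but uncertain. Compound 4 is estimated at 40%, within a range from 5% to 75%.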

Compound 4, a percentage reported as inhibition, at one concentration (the size of the read-out at that concentration, not a potency): 18.3%
Estimate against measurement, compound 4: 21.7 percentage points above; measured number inside the range.
By their numbers in this assay, from the lowest: compounds 3, 2 and 4 (each within the scatter of the next, the first and the last beyond it); then compound 1.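

Placing 4-bromophenyl at this position gives a number 17.9 percentage points higher from compound 3 to compound 4 (beyond the scatter) in this assay but only a number 9.2 percentage points higher from compound 2 to compound 4 (within the scatter) and so shows that a six-membered aromatic ring of carbon only does not by itself bring back the number of compound 1. Bromo in place of methoxy gives a number 50.1 percentage points lower from compound 1 to compound 4 (beyond the scatter) on the otherwise identical structure, which shows that the substituent on this ring matters a great deal here. Going by these compounds, it remains open whether an amine, a hydroxyl or a longer alkoxy chain on the same ring would match methoxy. Nothing measured here accounts for these steps.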